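This account rests on a few compounds, and the source may have more. Where it says the series, first, only, none or still open, it means among the compounds named here.

Measured compounds:
compound 1, `Cn1cc(C(=O)O)c2ccc(N3C(=O)CCc4cc(OCc5c(-c6c(Cl)cccc6Cl)noc5C5CC5)ccc43)cc21`: 43 nM
compound 2, `O=C1CCc2cc(OCc3c(-c4c(Cl)cccc4Cl)noc3C3CC3)ccc2N1c1ncc(O)cc1F`: 9 nM

In an assay on isolated protein for agonist activity at Bile acid receptor (Homo sapiens), read by AlphaScreen, with a stated time of 1 h (on this read-out higher numbers stand for an effect only at larger amounts of compound and lower numbers for an effect already at smaller amounts), compound 2 gives the lowest of the two numbers; compound 1, its nearest neighbour, gives a higher one, and that gap lies beyond the usual scatter. Compound 3, `O=C(O)c1ccc(N2C(=O)CCc3cc(OCc4c(-c5c(Cl)cccc5Cl)noc4C4CC4)ccc32)nc1`, has not been measured. It differs from compound 2 in one place: a group of 9 heavy atoms (6 carbon, 1 nitrogen, 2 oxygen; one six-membered aromatic ring with 1 hetero atom) in place of a group of 8 heavy atoms (5 carbon, 1 nitrogen, 1 oxygen, 1 fluorine; one six-membered aromatic ring with 1 hetero atom), on an amide-type nitrogen in a ring. Among the compounds with values here, no pair of measured compounds shows this change, so the expected step rests on compound 1 and compound 2 alone; a modest move toward a higher number is expected, of about a 2.2-fold higher number from compound 2 to compound 3 (0.35 log units; beyond the scatter). Compound 3 is therefore estimated at 20 nM in this assay, within a range from 5 nM to 80 nM.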

Compound 3, half-maximal effective concentration: 20 nM
Beside the measured number, compound 3's estimate shows no gap at the digits printed; measured number inside the range.
By their numbers in this assay, from the lowest: compound 2; then compound 3; then compound 1.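

At the amide-type nitrogen in a ring, the 5-carboxypyridin-2-yl group of compound 3 replaces the group of compound 2 at a modest cost in this assay, with a 2.2-fold higher number from compound 2 to compound 3 (0.35 log units; beyond the scatter). Within the data shown here, this gives the first direct one-place comparison at this position, and it shows that a change of group here shifts the number beyond the usual scatter while both groups have the same counted hydrogen-bond donors and acceptors. Nothing in the data at hand accounts for this step.

Because the two groups differ in several atoms at once, this single step cannot show which of those differences carries the shift. It also leaves open how this assay would respond to a methyl ester or a primary amide in place of the carboxylic acid on the 5-carboxypyridin-2-yl group.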